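Series notes: (dimethylamino)methyl added to compound 2

A few compounds are considered here, and "the series" means these few. Any claim that something is new, unique, unknown or untested is made for them only; others in the source may bear on it.

Two compounds of the shared core have numbers in a functional assay on HeLa cells (Homo sapiens) for inhibition, read by trypan blue exclusion, with a stated time of 72 h; on this read-out higher numbers stand for weaker inhibition of growth and lower numbers for stronger inhibition of growth. Compound 1 `C=CC[C@@]12CCN[C@@H]1n1c3nc4ccccc4cc3c(=O)c3cccc2c31` gives 16500 nM. Compound 2 `CC(C)(C)OC(=O)N1CC[C@@]2(CCO)c3cccc4c(=O)c5cc6cc(O)ccc6nc5n(c34)[C@@H]12` gives 13000 nM in this assay, the lowest of the two numbers, although its nearest neighbour, compound 1, stands within the scatter of it, so no order between the two is claimed.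

Compound 3 `CN(C)Cc1c(O)ccc2nc3c(cc12)c(=O)c1cccc2c1n3[C@H]1N(C(=O)OC(C)(C)C)CC[C@@]21CCO` has not yet been measured. It differs from compound 2 in one place: (dimethylamino)methyl in place of hydrogen on an aromatic carbon. For the measured compounds named here, no step between measured compounds of this kind is known, so the size of the change has to be estimated without a precedent. A modest step toward stronger inhibition of growth is expected, one that may still fall within the scatter. For compound 3 the estimate in this assay is 6500 nM with a range of 1500 nM to 25000 nM. This corresponds to an expected step of a 2.0-fold lower number from compound 2 to compound 3 (0.30 log units; within the scatter).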

Compound 3, concentration for 50% growth inhibition: 13000 nM
Compound 3: middle estimate off by 2.0-fold (0.30 log units), on the low side; measured number inside the range.
By their numbers in this assay, from the lowest: compounds 2, 3 and 1 (each within the scatter of the next).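

In this assay, for the compounds shown here, the step of no change at the digits printed from compound 2 to compound 3 (within the scatter) is the first reading of a single change: (dimethylamino)methyl in place of hydrogen on this aromatic carbon, ortho to a hydroxy group. The earlier compounds shown here gave no step, so they showed nothing about this position; it now carries this larger group with the number unmoved, though one flat step cannot show that the position is insensitive to substitution in general. No measured evidence bears on this result.

Still open, on these data alone, is whether a morpholinomethyl group, a primary aminomethyl group or a longer chain ending in dimethylamino would read differently at this carbon. Also open, as far as these compounds go, is whether (dimethylamino)methyl would give the same result without the hydroxy group on that ring.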